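The compounds below may be only part of what the source reports. "The series", "measured", "known", "first", "only" and "open" are said of these compounds alone.

Measured so far in a functional assay on the whole organism (strain Wistar) for inhibition, with Rattus norvegicus as the target, read by paw edema, with stated times of 60 min and 2 h, at a dose of 100 mg/kg by the oral route; a lower number here means less inhibition, a higher number more inhibition at the dose given (going by the name of the read-out):
Compound 1 `COc1cc2c(cc1OC)C(CC(=O)O)CC2`: 24%
Compound 2 `CCN(CC)C(=O)CC1CCc2cc(OC)c(OC)cc21`: 40%
Compound 3 `COc1cc2c(cc1OC)C(CC(=O)NC(C)(C)C)CC2`: 32%

Compound 3 stands second highest of the three numbers; its gap to compound 1 and its gap to compound 2 both lie within the usual scatter. Compound 4 `COc1cc2c(cc1OC)C(CC(=O)N1CCCCC1)CC2` is not yet measured and differs from compound 3 in one place: piperidin-1-yl in place of (tert-butyl)amino on a carbonyl carbon. Going by the values given here, three measured steps bear on this. Diethylamino in place of hydroxy gave a number 16 percentage points higher from compound 1 to compound 2 (beyond the scatter), (tert-butyl)amino in place of hydroxy gave a number 8 percentage points higher from compound 1 to compound 3 (within the scatter), and (tert-butyl)amino in place of diethylamino gave a number 8 percentage points lower from compound 2 to compound 3 (within the scatter). Piperidin-1-yl, like diethylamino, brings no hydrogen-bond donor. Compound 4 is thus expected to show a step of a number 6 percentage points higher from compound 3 to compound 4 (within the scatter), within the scatter, landing near the value of compound 2. The estimate for compound 4 is 38%, ranging from 26% to 50%.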

Compound 4, a percentage reported as inhibition, in the whole organism at one dose (the size of the read-out at that dose, not a potency): 22%
Beside the measured number, compound 4's estimate is 16 percentage points above it; the whole stated range lies above it.
By their numbers in this assay, from the lowest: compounds 4, 1, 3 and 2 (each within the scatter of the next, the first and the last beyond it).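

On the carbonyl carbon in this assay, piperidin-1-yl and diethylamino both bring no hydrogen-bond donor, yet they part ways (a number 18 percentage points lower from compound 2 to compound 4 (beyond the scatter)), so the missing donor alone does not set the number. The other two steps stay within the scatter (a number 10 percentage points lower from compound 3 to compound 4 (within the scatter); a number 2 percentage points lower from compound 1 to compound 4 (within the scatter)), leaving piperidin-1-yl not told apart from (tert-butyl)amino or hydroxy here. No measurement at hand accounts for the gap from diethylamino. Going by these compounds, whether pyrrolidin-1-yl or morpholin-4-yl on this carbonyl carbon would read like piperidin-1-yl or like diethylamino remains open.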